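The compounds below may be only part of what the source reports. "The series", "measured", "known", "first", "only" and "open" are said of these compounds alone.

The study collects two measured compounds in a functional assay on the whole organism (strain albino) for inhibition, with Rattus norvegicus as the target, read by paw edema, with stated times of 30 min and 2 h, at a dose of 100 mg/kg by the oral route (a lower number here means less inhibition, a higher number more inhibition at the dose given (going by the name of the read-out)), and turns to a third. Compound 1, `COc1ccc(C2CC(c3ccc(OC)c(OC)c3)=NN2)c(OC)c1`, carries two dimethoxyphenyl groups on its five-membered core, and in this assay compound 1 gives 39%. Compound 2, `COc1ccc(C2=NN(C(=O)CO[N+](=O)[O-])C(c3ccco3)C2)cc1OC`, bears a furan-2-yl on a saturated ring carbon and a ((nitrooxy)methyl)carbonyl group on the ring nitrogen, and in this assay compound 2 gives 37%. For the measured compounds named here, the two compounds differ in more than one place, so no single step joins them; what their two numbers show is that compound 2 sits alongside compound 1, the gap between them lying within the usual scatter of this kind of measurement.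

Compound 3, `COc1ccc(C2CC(c3ccc(OC)c(OC)c3)=NN2C(=O)CO[N+](=O)[O-])c(OC)c1`, is reached from compound 2 by one change: 2,4-dimethoxyphenyl in place of furan-2-yl on a saturated ring carbon. The new compound thus pairs the ((nitrooxy)methyl)carbonyl group of compound 2 with the two dimethoxyphenyl groups of compound 1. Since compound 1 at 39% and compound 2 at 37% cannot be told apart, no step beyond the scatter is expected in this assay; the expected step is a number 3 percentage points higher from compound 2 to compound 3 (within the scatter). For compound 3 the estimated value in this assay is 40%, with a range from 28% to 52%.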

Compound 3, a percentage reported as inhibition, in the whole organism at one dose (the size of the read-out at that dose, not a potency): 48%
For compound 3 the middle estimate is 8 percentage points below the measured one; the measured number falls inside the stated range.
By their numbers in this assay, from the lowest: compounds 2, 1 and 3 (each within the scatter of the next, the first and the last beyond it).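

In this assay, for the compounds shown here, with the ((nitrooxy)methyl)carbonyl group held in place on the ring nitrogen, the saturated ring carbon next to the ring nitrogen proves sensitive to its substituent: 2,4-dimethoxyphenyl in place of furan-2-yl gives a number 11 percentage points higher from compound 2 to compound 3 (beyond the scatter), the first single-place change in the set to pass beyond the scatter, though only modestly. The second single-place comparison concerns the ring nitrogen, where ((nitrooxy)methyl)carbonyl in place of hydrogen gives a number 9 percentage points higher from compound 1 to compound 3 (within the scatter), so the effect of this group on its own cannot be separated from the scatter of this assay. Nothing available accounts for the size of either step.

Going by these compounds, whether the step at the ring carbon depends on the methoxy groups remains open, since a plain phenyl or a pyridine ring at that place would be needed to tell the aryl ring from its substituents. On these data alone, it also remains open whether the nitrooxy part matters at the ring nitrogen, which a simple acetyl group or a longer chain carrying the nitrooxy group could help to decide.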